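Branching on the nitrogen-bound carbon in a cyanoguanidine series

The source may report more compounds than this note shows. Statements on the series, on what has been measured and on what is new or still open speak of the compounds shown alone.

Compound 3 `CC(C)(C)/N=C(\NC#N)Nc1ccncc1` gives 2.5 mg/kg in a functional assay on the whole organism (blood, strain Wistar-Okamoto) with Rattus norvegicus as the target, with a stated time of 5 days (a higher number here means that more compound is needed for the effect, a lower number that less compound is needed), the lowest of the three numbers shown, though within the scatter of both others: compound 2 `CC(/N=C(\NC#N)Nc1ccncc1)C1CC1` gives 3 mg/kg and compound 1 `CCC(/N=C(\NC#N)Nc1ccncc1)C(C)C` gives 5 mg/kg, and a 1.2-fold lower number from compound 2 to compound 3 (0.08 log units; within the scatter) as well as a 2.0-fold lower number from compound 1 to compound 3 (0.30 log units; within the scatter) stay within the scatter. Compound 4 `CC(C)(C)C(C)(C)/N=C(\NC#N)Nc1ccncc1` differs from compound 3 by tert-butyl in place of methyl on a saturated chain carbon bound to a double-bonded nitrogen and two saturated chain carbons. Among the compounds with values here, the steps that bear on this change are the three that alter the group on the double-bonded nitrogen, a 1.7-fold lower number from compound 1 to compound 2 (0.22 log units; within the scatter), a 2.0-fold lower number from compound 1 to compound 3 (0.30 log units; within the scatter) and a 1.2-fold lower number from compound 2 to compound 3 (0.08 log units; within the scatter), none of them beyond the scatter. No step beyond the scatter is therefore expected in this assay, in no settled direction, so that a 1.2-fold higher number from compound 3 to compound 4 (0.08 log units; within the scatter) is expected to be small. Compound 4 is expected to give 3 mg/kg, within 1.2 mg/kg to 8 mg/kg.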

Compound 4, minimum effective dose: 20 mg/kg
For compound 4 the middle estimate is 6.7-fold (0.82 log units) below the measured one; measured number outside the range, above it.
By their numbers in this assay, from the lowest: compounds 3, 2 and 1 (each within the scatter of the next); then compound 4.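

In this assay, within the data shown here, the change of tert-butyl in place of methyl gives an 8.0-fold higher number from compound 3 to compound 4 (0.90 log units; beyond the scatter) and is the only step beyond the scatter, whereas the three earlier changes of the group on the double-bonded nitrogen all stay within it. This position therefore does not accept every replacement without consequence, and a change here can move the minimum effective dose. Nothing shown accounts for the size of this step. Still open, going by these compounds, is whether ethyl or a longer chain in place of tert-butyl on this carbon behaves like methyl or like tert-butyl. An amine or a carboxylic acid at the same place also remains to be placed against these numbers.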